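Swapping the Aryl Group: What to Expect for Compound 4

This account rests on a few compounds, and the source may have more. Where it says the series, first, only, none or still open, it means among the compounds named here.

Compound 1, `Brc1ccc(-c2cc(COc3ccccc3-c3nc4ccccc4s3)on2)cc1`, gives 16400 nM
Compound 2, `COc1ccc(-c2cc(COc3ccccc3-c3nc4ccccc4s3)on2)cc1`, gives 20700 nM
Compound 3, `c1ccc(-n2cc(COc3ccccc3-c3nc4ccccc4s3)nn2)cc1`, gives 16600 nM

These three were tested in a functional assay on COLO 205 cells (Homo sapiens) for cytotoxicity, read by MTT assay, with a stated time of 24 h; on this read-out lower numbers stand for stronger inhibition and higher numbers for weaker inhibition. Their numbers lie within the scatter of one another: compound 2 is separated from compound 3 and from compound 1 by gaps too small to read as real differences. Compound 4, `Fc1ccccc1-c1cc(COc2ccccc2-c2nc3ccccc3s2)on1`, is not yet measured. It differs from compound 2 by 2-fluorophenyl in place of 4-methoxyphenyl on an aromatic carbon. Going by the values given here, the only measured step, a 1.3-fold higher number from compound 1 to compound 2 (0.10 log units; within the scatter), exchanged one substituent on the phenyl group and stayed within the scatter; it bears only loosely on this change, where the whole 4-methoxyphenyl gives way to 2-fluorophenyl. No step beyond the scatter is therefore expected. Compound 4 is estimated at 18000 nM, between 7000 nM and 45000 nM. The expected step is a 1.2-fold lower number from compound 2 to compound 4 (0.06 log units; within the scatter).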

Compound 4, half-maximal inhibitory concentration: 18300 nM
Compound 4: the middle estimate sits 1.0-fold (0.01 log units) below what was measured; the range from low to high includes it.
By their numbers in this assay, from the lowest: compounds 1, 3, 4 and 2 (each within the scatter of the next).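

Until now, only the group at the 4-position of the phenyl ring had changed; here the substituent itself and its place on the ring change together. Even so, 2-fluorophenyl in place of 4-methoxyphenyl gives a 1.1-fold lower number from compound 2 to compound 4 (0.05 log units; within the scatter), and in place of 4-bromophenyl it gives a 1.1-fold higher number from compound 1 to compound 4 (0.05 log units; within the scatter), so these three aryl groups cannot be told apart on this carbon next to the ring nitrogen. Nothing available explains why they read alike. As far as these compounds go, whether an amine or a carboxylic acid on the phenyl ring, or a longer chain replacing that ring, would move the number stays open.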